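Compound 4: acetyl in place of the boron group

This account rests on a few compounds, and the source may have more. Where it says the series, first, only, none or still open, it means among the compounds named here.

In a functional assay on MIA PaCa-2 cells (Homo sapiens) for cytotoxicity, read by MTT assay, with a stated time of 72 h (on this read-out higher numbers stand for weaker inhibition and lower numbers for stronger inhibition), compound 1 `O=C1C(NCc2ccc(F)cc2)=CC(=O)c2ncncc21` gives 1700 nM, and compound 2 `COc1cccc(NC2=CC(=O)c3ncncc3C2=O)c1` gives 1800 nM. Compound 3 `O=C1C(Nc2cccc(B(O)O)c2)=CC(=O)c2ncncc21` reads > 10000 nM, which is a limit of the assay and not a number. For the measured compounds named here, the one measured step that bears on what follows is an at least 5.5-fold higher number from compound 2 to compound 3 (0.74 log units; beyond the scatter), where the boron-bearing group came in. Compound 4 `CC(=O)c1cccc(NC2=CC(=O)c3ncncc3C2=O)c1` removes that group again, the change being (a group of 3 heavy atoms (2 carbon, 1 oxygen; no ring) in place of a group of 3 heavy atoms (1 boron, 2 oxygen; no ring), on an aromatic carbon). With it gone, the earlier step should largely reverse, leading back towards compound 2 and its 1800 nM. The expected step is an at least 4.5-fold lower number from compound 3 to compound 4 (0.65 log units; beyond the scatter), towards stronger inhibition. For compound 4 the estimate is 2200 nM, with an expected range of 700 nM to 7000 nM.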

Compound 4, half-maximal inhibitory concentration: 2300 nM
Compound 4: the middle estimate sits 1.0-fold (0.02 log units) below what was measured; the measured number falls inside the stated range.
By their numbers in this assay, from the lowest: compounds 1, 2 and 4 (each within the scatter of the next). At a limit, above all of these: compound 3.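

With acetyl on this aromatic carbon in place of the boron group, there is an at least 4.3-fold lower number from compound 3 to compound 4 (0.63 log units; beyond the scatter), so the weak reading does not extend to every group with this count of heavy atoms. Acetyl in place of methoxy gives a 1.3-fold higher number from compound 2 to compound 4 (0.11 log units; within the scatter), so the assay does not separate these two groups. Compound 3 stands at a limit and not at a number: the limit of > 10000 nM in this assay, at which 1 of the 4 values shown sits.

Going by these compounds, whether an amine or a carboxylic acid on this carbon would read like acetyl and methoxy, or like the boron group, stays open.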